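Compound 4: Mirror-Image Partner of an Unmeasured Compound

The compounds below may be only part of what the source reports. "The series", "measured", "known", "first", "only" and "open" are said of these compounds alone.

For the measured compounds named here, in a functional assay (aorta) with Rattus norvegicus as the target (a higher number here means that more compound is needed for the effect, a lower number that less compound is needed), only one compound in this small set has a number: compound 1 (`CC(C)C[C@@H](N)C(=O)Nc1cc2cc[nH]c(=O)c2cc1Cl`) gives 700 nM. Compound 2 (`N[C@@H](C(=O)Nc1cc2cc[nH]c(=O)c2cc1Cl)C1CCCCC1`) has no such number, and its entry reads "not determined" (no result reported). Compound 3 (`CN(C)[C@H]1CC[C@@H](C(=O)Nc2cc3cc[nH]c(=O)c3cc2Cl)CC1`) is in the same position, with the entry "not determined" (no result reported). Compound 2 therefore holds no rank at all, and it offers no starting value for the next step.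

That step leads to compound 4 (`N[C@H](C(=O)Nc1cc2cc[nH]c(=O)c2cc1Cl)C1CCCCC1`): the two compounds have the same atoms and bonds and differ only in configuration as drawn: 1 of 1 stereo elements differ; a stereocentre at a saturated chain carbon is drawn R in compound 2 and S in compound 4. No atom is gained or lost, so only the spatial arrangement differs. Going by the values given here, no measured pair here shows what such a switch does in this assay, so neither the size nor the direction of the step from compound 2 can be predicted. The nearest guide is compound 1 at 700 nM, and a result near that value, with no clear shift beyond the scatter, is the cautious expectation. For compound 4 the expected value is 1000 nM, with an estimated range from 200 nM to 5000 nM.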

Compound 4, half-maximal effective concentration: 180 nM
Compound 4: the middle estimate sits 5.6-fold (0.74 log units) above what was measured; measured number below the stated range.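

No new step can be read here: compound 4 has a value in this assay, but compound 2 has no single number to set against it. The compounds shown leave open how far, and in which direction, this switch in configuration moves the value.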